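The source may report more compounds than this note shows. Statements on the series, on what has been measured and on what is new or still open speak of the compounds shown alone.

Compound 1 `CC(=O)N1CCC(C(=O)N(CCCN2CCN(Cc3ccncc3)CC2)c2ccc(C)c(Cl)c2)CC1` gives > 56700 nM in an ADME assay (Homo sapiens) for cytotoxicity; a higher number here means that more compound is tolerated, a lower number that less compound is tolerated.
Compound 2 `CC(=O)N1CCC(C(=O)N(CCCN2CCC(CNc3ncccn3)CC2)c2ccc(C)c(Cl)c2)CC1` gives > 55100 nM in this assay.

Within the data shown here, both values so far are limits of this assay and not numbers. The value of compound 1 in this assay is a limit; it sits at the limit of > 56700 nM in this assay, at which 1 of the 2 values shown sits. The value of compound 2 in this assay is also a limit; it sits at the limit of > 55100 nM in this assay, at which 1 of the 2 values shown sits. So compound 1 stands at a limit, and every value in this assay is a limit, with nothing to order the two compounds against each other.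

Compound 3 `CC(=O)N1CCC(C(=O)N(CCCN2CCN(Cc3cnc(Cl)s3)CC2)c2ccc(C)c(Cl)c2)CC1` differs from compound 1 by a single change: 2-chloro-1,3-thiazol-5-yl in place of pyridin-4-yl on a saturated chain carbon bound to an amine nitrogen in a ring. Among the measured compounds shown here, no step between two measured compounds is known here, so there is nothing to compare this change against. Given that compound 1 sits at a limit (> 56700 nM), no step beyond the scatter is expected for compound 3, and the step of a number no higher from compound 1 to compound 3 (the limit leaves the size open) is estimated as essentially flat. Compound 3 is expected to give about 56700 nM, within 28000 nM to 120000 nM, most likely again only a limit.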

Compound 3, half-maximal cytotoxic concentration: > 52300 nM
Compound 3: only a limit was reported; the forecaster's own chance of this, stated with the estimate: 85%; the middle value lies beyond the limit too.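

The values of compound 1 and compound 3 in this assay are both limits, and the step between them cannot be read. The compounds shown leave open at what concentration each becomes cytotoxic, and whether 2-chloro-1,3-thiazol-5-yl in place of pyridin-4-yl shifts that concentration at all.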